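One Aryl Change on the Urea of Compound 2

This account rests on a few compounds, and the source may have more. Where it says the series, first, only, none or still open, it means among the compounds named here.

Measured so far in a functional assay on NCI-H522 cells (Homo sapiens) for inhibition, read by sulforhodamine B assay, with a stated time of 48 h; on this read-out lower numbers stand for higher toxicity in this test and higher numbers for lower toxicity in this test:
- compound 1, `COc1cc(-c2nn(-c3cccc(NC(=O)Nc4cc(C(F)(F)F)cc(C(F)(F)F)c4)c3)cc2-c2ccncc2)ccc1Cl`, gives 6560 nM in this assay.
- compound 2, `COc1cc(-c2nn(-c3cccc(NC(=O)Nc4ccc(Cl)c(Cl)c4)c3)cc2-c2ccncc2)ccc1Cl`, reaches only the limit of the assay, > 50000 nM, in this assay.

Compound 2 therefore stands at the limit of > 50000 nM in this assay, at which 1 of the 2 values shown sits, not at a measured number, while compound 1 sits at a definite value. Compound 3, `COc1cc(-c2nn(-c3cccc(NC(=O)Nc4cccc(C(F)(F)F)c4)c3)cc2-c2ccncc2)ccc1Cl`, differs from compound 2 in one place: 3-(trifluoromethyl)phenyl in place of 3,4-dichlorophenyl on an amide-type nitrogen. Going by the values given here, no step between measured compounds is given for this change, so its size cannot be read off. Compound 1 carries two trifluoromethyl groups on the same ring and gives a measured number, whereas compound 2 with its 3,4-dichlorophenyl shows only the limit. Compound 3 with a single trifluoromethyl group is expected to land between the two, as a measured value lower than the limit of compound 2, with the step of an at least 2.5-fold lower number from compound 2 to compound 3 (0.39 log units; beyond the scatter) estimated only roughly because compound 2 is itself a limit. Compound 3 is estimated at 20000 nM, within 6000 nM to 50000 nM, in this assay.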

Compound 3, concentration lethal to 50% of the cells: > 50000 nM
Compound 3: a limit, no number; the forecaster's own chance of this, stated with the estimate: 35%; middle value at least 2.5-fold (0.39 log units) away from the limit.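

In this assay compound 3 gives > 50000 nM as a limit of the assay and not a number. The step of an at least 7.6-fold higher number from compound 1 to compound 3 (0.88 log units; beyond the scatter) comes with hydrogen in place of trifluoromethyl on an aromatic carbon, so this single change on the ring is enough to take the measured number of compound 1 to the limit, and one trifluoromethyl group on this ring does not by itself give a measured value. The change from 3,4-dichlorophenyl to 3-(trifluoromethyl)phenyl on the amide-type nitrogen yields no step that can be read, and among the compounds shown only compound 1 gives a measured number, with the others held at one limit: the limit of > 50000 nM in this assay, at which 2 of the 3 values shown sit.

From the compounds shown here alone, how far the true values of compound 2 and compound 3 lie past the limit remains unknown, and so does which of the two stands lower. Also open, going by these compounds, is how this assay would read a nitrile, a methoxy group or an amine on this ring in place of the trifluoromethyl group of compound 3.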